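The source may hold more compounds than are shown below. What is called first, only, known or untested is meant among the compounds shown, and "the series" means these compounds.

Compound 2 `C=C(Br)C(=O)Nc1ccc(/C=C2\SC(=O)N(Cc3ccc(F)cc3)C2=O)cc1` and compound 1 `C=C(Br)C(=O)Nc1ccc(/C=C2\SC(=O)N(Cc3ccccc3)C2=O)cc1` share one core and differ in a single place: hydrogen in place of fluoro on an aromatic carbon. In a functional assay on FM3A cells (Mus musculus) for cytotoxicity, read by cell counting, with a stated time of 2 days (a lower number here means a stronger inhibitor, a higher number a weaker inhibitor), compound 2 gives 4600 nM, and compound 1 gives 3000 nM, which is a 1.5-fold lower number from compound 2 to compound 1 (0.19 log units; within the scatter). Compound 3 `C=C(Br)C(=O)Nc1cccc(/C=C2\SC(=O)N(Cc3ccc(F)cc3)C2=O)c1` is built on a different core; the difference between the two cores is not broken down here. In this assay compound 3 gives 920 nM, the lowest of the three numbers and beyond the scatter from both others. Among the compounds with values here, compound 4 `C=C(Br)C(=O)Nc1cccc(/C=C2\SC(=O)N(Cc3ccccc3)C2=O)c1` differs from compound 3 by the same change as the one between compound 2 and compound 1: hydrogen in place of fluoro on an aromatic carbon. Because the step of a 1.5-fold lower number from compound 2 to compound 1 (0.19 log units; within the scatter) lay within the scatter, the number for compound 4 is expected to stay close, a step of a 1.3-fold lower number from compound 3 to compound 4 (0.12 log units; within the scatter). The estimated value for compound 4 in this assay is 700 nM, expected to fall between 300 nM and 1800 nM.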

Compound 4, half-maximal inhibitory concentration: 810 nM
The estimate for compound 4 lay 1.2-fold (0.06 log units) below the measured number; the measured number falls inside the stated range.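

In this assay, putting hydrogen in place of the fluoro on the 4-fluorobenzyl group gives a 1.1-fold lower number from compound 3 to compound 4 (0.06 log units; within the scatter). The change therefore behaves alike on both cores, with neither step standing out from the scatter and the two steps agreeing: the same change on two cores in this assay, a 1.5-fold lower number (0.19 log units; within the scatter) from compound 2 to compound 1 and a 1.1-fold lower number (0.06 log units; within the scatter) from compound 3 to compound 4, 1.4-fold (0.13 log units) apart, within the scatter of two such steps. This shows that, for these two pairs in this cell-counting test, the swap carries from one core to the other with no readable effect, but two pairs set no rule for other cores or other assays.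

The compounds shown leave open what a larger or differently built group in that place, such as a methoxy group, an amine or a carboxylic acid, would do to the number.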